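From 3-methylphenyl to furan-2-yl at the assay limit

The source may report more compounds than this note shows. Statements on the series, on what has been measured and on what is new or still open speak of the compounds shown alone.

Compound 1 `COc1cc(-c2cccc3nc(-c4ccc(F)cc4)oc23)cc(OC)c1OC`: > 25000 nM
Compound 2 `COc1cc(-c2cccc3nc(-c4cccc(C)c4)oc23)cc(OC)c1OC`: > 25000 nM

Both entries come from a functional assay on MCF7 cells (Homo sapiens) for antiproliferative activity, read by MTT assay, with a stated time of 48 h (on this read-out lower numbers stand for stronger inhibition and higher numbers for weaker inhibition), and neither is a number. In this assay compound 2 gives > 25000 nM, which is a limit. Its standing therefore amounts to the limit of > 25000 nM in this assay, at which 2 of the 2 values shown sit.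

Compound 3 `COc1cc(-c2cccc3nc(-c4ccco4)oc23)cc(OC)c1OC` has not yet been measured. It carries furan-2-yl in place of 3-methylphenyl on an aromatic carbon of a five-membered aromatic ring with 1 nitrogen and 1 oxygen, part of a fused or bridged system of two rings: furan-2-yl in place of 3-methylphenyl on an aromatic carbon.

Among the measured compounds shown here, one measured step bears on this change, also an exchange of one aromatic group for another: a step that the two limits leave unreadable from compound 1 to compound 2. It offers no size to carry over, so no readable step is expected in this assay and no direction can be favoured. The expected change is a step that the limit leaves unreadable from compound 2 to compound 3, and this remains an estimate. A report of a limit alone is the likeliest outcome. For compound 3 the estimated value is 30000 nM, with an expected range of 10000 nM to 60000 nM.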

Compound 3, half-maximal inhibitory concentration: > 25000 nM
Compound 3: only a limit was reported (the forecaster's own chance of this, stated with the estimate: 70%); the middle value is on the limit's open side.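

No step can be read among compound 1, compound 2 and compound 3, since each is reported only as a limit and not as a number: the limit of > 25000 nM in this assay, at which 3 of the 3 values shown sit.

The compounds shown leave open how strongly each one acts in this assay, and whether exchanging the aromatic group on the shared core changes that at all.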